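The compounds below may be only part of what the source reports. "The series", "measured", "known", "first", "only" and "open" are said of these compounds alone.

Measured so far in an assay on brain (strain Sprague-Dawley) for displacement of a labelled ligand from sodium-dependent dopamine transporter (Rattus norvegicus), read by scintillation counting, with a stated time of 120 min; a higher number here means a weaker inhibitor, a lower number a stronger inhibitor:

Compound 1, `CNC(=O)C[S+]([O-])C(c1ccccc1)c1ccccc1`, gives 13100 nM.
Compound 2, `c1ccc(CCCNCCSC(c2ccccc2)c2ccccc2)cc1`, gives 295 nM.
Compound 3, `[O-][S+](CCNCCCc1ccccc1)C(c1ccc(Cl)cc1)c1ccc(Cl)cc1`, gives 645 nM.

Compound 1 has the highest number of the three, and its gaps to compound 3 and to compound 2 both lie beyond the scatter, so it is the weakest inhibitor shown. Compound 4, `CCCCNCC[S+]([O-])C(c1ccccc1)c1ccccc1`, differs from compound 1 in one place: (butylamino)methyl in place of methylcarbamoyl on a saturated chain carbon bound to a sulfur. Compound 2 and compound 3, which both carry a basic amine on the chain rather than a methylcarbamoyl, stand far lower than compound 1, and compound 4 keeps that amine. Going by the values given here, no step between measured compounds is available, yet the change is expected to bring a large decrease, an 8.7-fold lower number from compound 1 to compound 4 (0.94 log units; beyond the scatter). Compound 4 is therefore expected to give about 1500 nM in this assay, with a range from 500 nM to 5000 nM.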

Compound 4, inhibition constant: 1570 nM
For compound 4 the middle estimate is 1.0-fold (0.02 log units) below the measured one; the range from low to high includes it.
By their numbers in this assay, from the lowest: compound 2; then compound 3; then compound 4; then compound 1.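

In this assay, putting (butylamino)methyl in place of methylcarbamoyl on a saturated chain carbon bound to a sulfur brings an 8.3-fold lower number from compound 1 to compound 4 (0.92 log units; beyond the scatter). Going by these compounds alone, this is the first reading of a change at this place with the rest of the molecule held the same, and it shows that the number responds to this place on the chain. Nothing measured here accounts for the step.

The step cannot separate the amine from its butyl chain, as both enter together. As far as these compounds go, how a methylamino group, a dimethylamino group or a carboxylic acid would read at this place remains open.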